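The source may hold more compounds than are shown below. What is called first, only, known or untested is meant among the compounds shown, and "the series" means these compounds.

Compound 1 `CCCc1nc(-c2ccccc2)c(CNCCN2CCN(c3ccc(Cl)cc3)CC2)o1` carries a 4-chlorophenyl on the ring nitrogen of its piperazine-like ring; in an assay on HEK293 cells for inhibition of Voltage-dependent T-type calcium channel subunit alpha-1G (Homo sapiens), read by patch clamp (on this read-out higher numbers stand for weaker inhibition and lower numbers for stronger inhibition), compound 1 gives 2820 nM. Its two measured neighbours, compound 2 `CCCc1nc(-c2ccccc2)c(CNCCN2CCN(c3cccc(C(F)(F)F)c3)CC2)o1` with 1940 nM and compound 3 `CCCc1nc(-c2ccccc2)c(CNCCN2CCN(c3cccc(F)c3)CC2)o1` with 3350 nM, do not separate from it beyond the scatter: the number moves a 1.5-fold lower number from compound 1 to compound 2 (0.16 log units; within the scatter) and a 1.2-fold higher number from compound 1 to compound 3 (0.07 log units; within the scatter), and between them a 1.7-fold higher number from compound 2 to compound 3 (0.24 log units; within the scatter). Compound 4 `CCCc1nc(-c2ccccc2)c(CNCCN2CCN(c3ccccc3C)CC2)o1` has not been measured in this assay. It differs from compound 1 by 2-methylphenyl in place of 4-chlorophenyl on an amine nitrogen in a ring. The two steps that bear on this change are the aryl swaps at the same ring nitrogen, from compound 1 to compound 2 and from compound 1 to compound 3, both within the scatter, so an unmeasured aryl swap at that nitrogen is expected to give no step beyond the scatter in either direction. Compound 4 is therefore estimated at 2800 nM, within 1200 nM to 6500 nM, which means an expected step of a 1.0-fold lower number from compound 1 to compound 4 (0.00 log units; within the scatter).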

Compound 4, half-maximal inhibitory concentration: 4300 nM
Compound 4: middle estimate off by 1.5-fold (0.19 log units), on the low side; the measured number falls inside the stated range.
By their numbers in this assay, from the lowest: compounds 2, 1, 3 and 4 (each within the scatter of the next, the first and the last beyond it).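

In this assay, the 2-methylphenyl group of compound 4 gives the only step beyond the scatter among these aryl groups on the ring nitrogen, a modest one of a 2.2-fold higher number from compound 2 to compound 4 (0.35 log units; beyond the scatter). Against the other two aryl groups it does not separate, at a 1.5-fold higher number from compound 1 to compound 4 (0.18 log units; within the scatter) and a 1.3-fold higher number from compound 3 to compound 4 (0.11 log units; within the scatter), so the four compounds form a narrow band in which only compound 2 and compound 4 stand apart. No supporting data bear on why this one pair separates.

As far as these compounds go, it remains open whether an unsubstituted phenyl, or a phenyl carrying a methoxy group or a carboxylic acid, would stay within this band. From the compounds shown here alone, it is also open whether the small gap between 2-methylphenyl and 3-(trifluoromethyl)phenyl would hold on a different core.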